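Swapping the Aryl Group on the Ketone Carbon

The source may hold more compounds than are shown below. What is called first, only, known or untested is meant among the compounds shown, and "the series" means these compounds.

Compound 1 `COc1ccc(C(=O)/C=C/c2cc(-c3ccc(OC)c(OC)c3)n3nc(-c4ccccc4)cc3n2)cc1OC`: 2600 nM
Compound 2 `COc1cc(-c2cc(/C=C/C(=O)c3ccc(C)c(C)c3)nc3cc(-c4ccccc4)nn23)cc(OC)c1OC`: 13500 nM
Compound 3 `COc1ccc(-c2cc(/C=C/C(=O)c3ccc(C)cc3)nc3cc(-c4ccccc4)nn23)cc1OC`: 19800 nM

These three compounds share a core and differ in the aryl group attached to the carbonyl carbon. In a functional assay on MDA-MB-231 cells (Homo sapiens) for antiproliferative activity, read by MTT assay, with a stated time of 24 h (on this read-out higher numbers stand for weaker inhibition and lower numbers for stronger inhibition), compound 2 gives the second highest of the three numbers. Its number sits within the usual scatter of that of compound 3, so the two cannot be told apart, while compound 1 gives a clearly lower number, a gap beyond the scatter.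

Compound 4 `COc1cc(-c2cc(/C=C/C(=O)c3ccc(Cl)cc3)nc3cc(-c4ccccc4)nn23)cc(OC)c1OC` is obtained from compound 2 by one change: 4-chlorophenyl in place of 3,4-dimethylphenyl on a carbonyl carbon. Going by the values given here, the only measured step that touches the same place is a 7.6-fold higher number from compound 1 to compound 3 (0.88 log units; beyond the scatter), where a 4-methylphenyl replaced a 3,4-dimethoxyphenyl on the carbonyl carbon. That step shows that exchanging the aryl group on the carbonyl carbon can shift the number by a modest amount, but the groups involved there are not the ones exchanged here, so no direction can be read from it with confidence. The expectation is therefore a step of no more than modest size, most likely within the scatter, with a little room on the side of a higher number: a 1.1-fold higher number from compound 2 to compound 4 (0.05 log units; within the scatter). Compound 4 is thus estimated at 15000 nM, between 5000 nM and 45000 nM in this assay.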

Compound 4, half-maximal inhibitory concentration: 32500 nM
For compound 4 the middle estimate is 2.2-fold (0.34 log units) below the measured one; the range from low to high includes it.
By their numbers in this assay, from the lowest: compound 1; then compounds 2, 3 and 4 (each within the scatter of the next, the first and the last beyond it).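

In this assay, putting 4-chlorophenyl in place of 3,4-dimethylphenyl on the carbonyl carbon gives a 2.4-fold higher number from compound 2 to compound 4 (0.38 log units; beyond the scatter), so this position responds even to an exchange between two aryl groups that have no hydrogen-bond donors or acceptors, and not only to the loss of the 3,4-dimethoxyphenyl group seen earlier. Together with a 7.6-fold higher number from compound 1 to compound 3 (0.88 log units; beyond the scatter), this makes two steps at this carbonyl carbon, and both end on a higher number, meaning weaker inhibition, although two pairs are far too few to support a general rule. Nothing at hand explains why this exchange moves the number.

From the compounds shown here alone, it remains open whether the step comes from adding the chlorine or from removing the two methyl groups, a question that a plain phenyl on the carbonyl carbon, joined to the rest of compound 2, could help to settle. Going by these compounds, how the number would respond to an aryl group on that carbon carrying an amine or a carboxylic acid also remains unknown.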